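The source may hold more compounds than are shown below. What is called first, only, known or untested is meant among the compounds shown, and "the series" means these compounds.

Of the compounds shown here, three that share one core have been tested in an ADME assay on the whole organism for cytotoxicity, with Artemia salina as the target, with a stated time of 24 h; on this read-out higher numbers stand for an effect only at larger amounts of compound and lower numbers for an effect already at smaller amounts. Compound 1 `Cc1ccc(/C=C/C(=O)c2ccccc2NC(=O)NS(=O)(=O)c2ccc(C)cc2)cc1` gives 15.3 ug/mL. Compound 2 `COc1ccc(/C=C/C(=O)c2ccccc2NC(=O)NS(=O)(=O)c2ccc(C)cc2)cc1` gives 28.1 ug/mL, and compound 3 `Cc1ccc(S(=O)(=O)NC(=O)Nc2ccccc2C(=O)/C=C/c2ccc(O)cc2)cc1` gives 24.3 ug/mL. Among these three numbers compound 3 holds the second highest, with compound 2 nearest and compound 1 furthest, yet every gap stays inside the usual scatter of this kind of measurement.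

Compound 4 `COc1cc(/C=C/C(=O)c2ccccc2NC(=O)NS(=O)(=O)c2ccc(C)cc2)ccc1O` differs from compound 3 in one place: methoxy in place of hydrogen on an aromatic carbon. The measured steps that speak to such a change are those in which a methoxy group took part. There was a 1.8-fold higher number from compound 1 to compound 2 (0.26 log units; within the scatter), and there was a 1.2-fold lower number from compound 2 to compound 3 (0.06 log units; within the scatter). For completeness, a 1.6-fold higher number from compound 1 to compound 3 (0.20 log units; within the scatter). None of these three steps left the scatter, so adding or removing small groups on this ring has not so far shifted the read-out in a way that can be trusted.

For compound 4 the expectation is therefore no step beyond the scatter, in either direction, and the estimate is a 1.0-fold lower number from compound 3 to compound 4 (0.01 log units; within the scatter). The expected value for compound 4 in this assay is 24 ug/mL, with a range from 12 ug/mL to 48 ug/mL.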

Compound 4, concentration for half-maximal effect: 17.8 ug/mL
Compound 4: middle estimate off by 1.3-fold (0.13 log units), on the high side; the measured number falls inside the stated range.
By their numbers in this assay, from the lowest: compounds 1, 4, 3 and 2 (each within the scatter of the next).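

A methoxy group added to the ring, ortho to a hydroxy group and meta to a large group, gives a 1.4-fold lower number from compound 3 to compound 4 (0.14 log units; within the scatter) in this assay and so does not move the read-out beyond the scatter, even with the hydroxy group kept in place. Exchanging a whole ring group tells the same story: 4-hydroxy-3-methoxyphenyl in place of 4-methoxyphenyl gives a 1.6-fold lower number from compound 2 to compound 4 (0.20 log units; within the scatter) and in place of 4-methylphenyl gives a 1.2-fold higher number from compound 1 to compound 4 (0.07 log units; within the scatter) and neither step leaves the scatter, so a ring carrying two groups reads like the rings carrying one. No measurement is available that could explain why these numbers stay so close together.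

Going by these compounds, all four compounds carry only methyl, methoxy or hydroxy on this ring, so it remains open whether an amine, a carboxylic acid or a longer chain there would shift the read-out beyond the scatter. The rest of the shared core is the same throughout, which leaves open how a change elsewhere in the molecule would register in this assay as well.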